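The source may hold more compounds than are shown below. What is called first, only, known or untested is meant among the compounds shown, and "the series" means these compounds.

Measured compounds, half-maximal inhibitory concentration in an assay on isolated protein (Cavia porcellus) with Sigma non-opioid intracellular receptor 1 (Homo sapiens) as the target, read by radioligand binding; on this read-out lower numbers stand for stronger inhibition and higher numbers for weaker inhibition:
Compound 1, `CN(C)CCCCCCCCCCOc1ccc2oc(-c3ccccc3)cc(=O)c2c1`: 341 nM
Compound 2, `O=c1cc(-c2ccccc2)oc2ccc(OCCCCCCN3CCCCC3)cc12`: 54 nM
Compound 3, `CCN(CC)CCCCCCOc1ccc2oc(-c3ccccc3)cc(=O)c2c1`: 100 nM

Compound 2 gives the lowest number of the three in this assay, but its gap to compound 3 is within the scatter, so the two cannot be ranked against each other; only compound 1 is clearly set apart, as a 6.3-fold lower number from compound 1 to compound 2 (0.80 log units; beyond the scatter) and a 3.4-fold lower number from compound 1 to compound 3 (0.53 log units; beyond the scatter) show. The step of a 1.9-fold higher number from compound 2 to compound 3 (0.27 log units; within the scatter) adds nothing beyond noise.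

Compound 4, `O=c1cc(C2CCCCC2)oc2ccc(OCCCCCCN3CCCCC3)cc12`, keeps the whole chain and amine of compound 2 and changes only the group on the shared core: cyclohexyl in place of phenyl on an aromatic carbon. Among the compounds with values here, none of the measured steps touches this position; all three concern the amine end of the chain, so they give no direct guide to the size or direction of this change. Within the data shown here, with no measured step bearing on it, the working expectation is a step of no more than the usual scatter, in either direction, so that the estimated step for compound 4 is a 1.3-fold higher number from compound 2 to compound 4 (0.11 log units; within the scatter). Among the measured compounds shown here, the estimate for compound 4 in this assay is 70 nM, with a range from 20 nM to 250 nM, the width reflecting that no measured compound informs this change.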

Compound 4, half-maximal inhibitory concentration: 32 nM
For compound 4 the middle estimate is 2.2-fold (0.34 log units) above the measured one; measured number inside the range.
By their numbers in this assay, from the lowest: compounds 4, 2 and 3 (each within the scatter of the next, the first and the last beyond it); then compound 1.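

In this assay, within the data shown here, the change on the aromatic carbon next to the ring oxygen gives a 1.7-fold lower number from compound 2 to compound 4 (0.23 log units; within the scatter), the first step that reads on this position rather than on the amine end of the chain. For this pair, with the chain and piperidin-1-yl end held fixed, a six-membered aromatic ring of carbon only and a six-membered non-aromatic ring of carbon only cannot be told apart at this position. The result therefore shows that, in this one setting, the aromatic character of the group at this position is not needed to keep the number within the scatter of that of compound 2, and nothing at hand accounts for this outcome.

Going by these compounds, it remains open whether cyclohexyl in place of phenyl would give a similarly small step with the diethylamino end of compound 3 or the 4-(dimethylamino)butyl end of compound 1. Also open, on these data alone, is whether a much smaller group such as methyl, a ring carrying nitrogen such as pyridyl, or a phenyl bearing a carboxylic acid would move the number at this position beyond the scatter.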